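The source may hold more compounds than are shown below. What is called first, only, known or untested is meant among the compounds shown, and "the series" means these compounds.

Measured compounds in a functional assay on HeLa cells (Homo sapiens) for antiproliferative activity, read by CCK-8 assay, with a stated time of 48 h; a higher number here means a weaker inhibitor, a lower number a stronger inhibitor:
compound 1 `CC(C)CSc1n[nH]c(-n2[se]c3ccccc3c2=O)n1` gives 34900 nM
compound 2 `Cc1cccc(CSc2n[nH]c(-n3[se]c4ccccc4c3=O)n2)c1` gives 42600 nM
compound 3 `CC(C)Sc1n[nH]c(-n2[se]c3ccccc3c2=O)n1` gives 34600 nM

Compound 3 holds the lowest of the three numbers, though its gap to compound 1 and to compound 2 stays within the scatter, so no order among the three can be read.

Compound 4 `CCCSc1n[nH]c(-n2[se]c3ccccc3c2=O)n1` differs from compound 3 by propyl in place of isopropyl on a sulfur. Going by the values given here, the steps that bear on this change are the earlier alterations on the same sulfur: a 1.0-fold lower number from compound 1 to compound 3 (0.00 log units; within the scatter) and a 1.2-fold lower number from compound 2 to compound 3 (0.09 log units; within the scatter), both flat. Swapping one small alkyl group for another on that sulfur has so far left this assay unmoved, so the step of a 1.0-fold higher number from compound 3 to compound 4 (0.00 log units; within the scatter) is expected to lie within the scatter, without a clear direction. Compound 4 is therefore estimated at 35000 nM, within a range of 20000 nM to 62000 nM.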

Compound 4, half-maximal inhibitory concentration: 30400 nM
The estimate for compound 4 lay 1.2-fold (0.06 log units) above the measured number; measured number inside the range.
By their numbers in this assay, from the lowest: compounds 4, 3, 1 and 2 (each within the scatter of the next).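

Propyl in place of isopropyl on a sulfur is a change of chain shape alone, and in this assay it gives a 1.1-fold lower number from compound 3 to compound 4 (0.06 log units; within the scatter). Set against the other two groups, the same propyl gives a 1.1-fold lower number from compound 1 to compound 4 (0.06 log units; within the scatter) and a 1.4-fold lower number from compound 2 to compound 4 (0.15 log units; within the scatter), so propyl, isopropyl, isobutyl and 3-methylbenzyl on this sulfur cannot be ordered, and all steps stay within the scatter. Nothing at hand accounts for this flatness.

Open, as far as these compounds go, is whether a longer chain, an amine or a carboxylic acid on that sulfur would move the number beyond the scatter. Also open, from the compounds shown here alone, is how a change to the shared core itself would read.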